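Fluoro for Nitro in a Small Cytotoxicity Series

This account rests on a few compounds, and the source may have more. Where it says the series, first, only, none or still open, it means among the compounds named here.

Measured compounds:
compound 1 `COc1cc(N(C)C(=O)c2cccc([N+](=O)[O-])c2)cc(OC)c1OC`: >= 125000 nM
compound 2 `COc1cc(N(C)C(=O)N(C)c2ccc(F)cc2)cc(OC)c1OC`: >= 125000 nM
compound 3 `COc1cc(N(C)C(=O)N(C)c2ccc([N+](=O)[O-])cc2)cc(OC)c1OC`: >= 125000 nM

In a functional assay on Daoy cells (Homo sapiens) for cytotoxicity, read by MTT assay, with a stated time of 72 h (on this read-out lower numbers stand for stronger inhibition and higher numbers for weaker inhibition), compound 1 gives >= 125000 nM, which is a limit of the assay and not a number. Compound 2 gives >= 125000 nM, also a limit. Compound 3 gives >= 125000 nM, again a limit. All three values therefore share (the limit of >= 125000 nM in this assay, at which 3 of the 3 values shown sit), and no ordering among them can be read.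

From compound 3 to compound 2 the change is fluoro in place of nitro on an aromatic carbon, and the step is a step that the two limits leave unreadable from compound 3 to compound 2. The difference between the core of compound 1 and the core of compound 3 is not broken down here.

Compound 4 `COc1cc(N(C)C(=O)c2cccc(F)c2)cc(OC)c1OC` is not yet measured. It differs from compound 1 by fluoro in place of nitro on an aromatic carbon. This is the same kind of change as that from compound 3 to compound 2, but around the place it differs: there the fluoro stands para to a large group, here meta to a large group.

The expected step from compound 1 to compound 4 is a number no higher from compound 1 to compound 4 (the limit leaves the size open), resting on compound 1 at >= 125000 nM and on the unreadable step that the two limits leave unreadable from compound 3 to compound 2. Compound 4 is estimated at 125000 nM, from 50000 nM to 200000 nM, most likely reported once more as a limit.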

Compound 4, half-maximal inhibitory concentration: >= 125000 nM
Compound 4: a limit, no number (the forecaster's own chance of this, stated with the estimate: 85%); the middle value lies on the limit itself.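

In this assay compound 4 gives >= 125000 nM, which is a limit of the assay and not a number. With compound 1 at that same limit, no step can be read from compound 1 to compound 4: the limit of >= 125000 nM in this assay, at which 4 of the 4 values shown sit.

The compounds shown leave open whether fluoro and nitro differ at all here, and how strongly any of the four compounds acts on these cells.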